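A few compounds are considered here, and "the series" means these few. Any claim that something is new, unique, unknown or untested is made for them only; others in the source may bear on it.

Measured in a functional assay on HUVEC cells (Homo sapiens), read by scintillation counting and thymidine incorporation, with a stated time of 24 h; on this read-out lower numbers stand for stronger inhibition and higher numbers for weaker inhibition:
compound 1 `CCC(C)n1ncn(-c2ccc(N3CCN(c4ccc(OC[C@@H]5CO[C@@](CN(C)C)(c6ccc(Cl)cc6Cl)O5)cc4)CC3)cc2)c1=O` — 1400 nM
compound 2 `CCc1nccn1C[C@@]1(c2ccc(Cl)cc2Cl)OC[C@@H](COc2ccc(N3CCN(c4ccc(-n5cnn(C(C)CC)c5=O)cc4)CC3)cc2)O1` — 224 nM
compound 3 `CCC(C)n1ncn(-c2ccc(N3CCN(c4ccc(OC[C@@H]5CO[C@@](Cn6ccnc6C(C)C)(c6ccc(Cl)cc6Cl)O5)cc4)CC3)cc2)c1=O` — 84 nM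

Compound 1 stands at the highest number of the three in this assay, with compound 2 nearest and compound 3 furthest. Compound 4 `CCC(C)n1ncn(-c2ccc(N3CCN(c4ccc(OC[C@@H]5CO[C@@](Cn6cnc(C)c6)(c6ccc(Cl)cc6Cl)O5)cc4)CC3)cc2)c1=O` is not yet measured; its change from compound 1 is 4-methyl-1H-imidazol-1-yl in place of dimethylamino on a saturated chain carbon bound to a saturated ring carbon.

Among the compounds with values here, two measured steps bear on this change, both replacing dimethylamino on the same carbon by an imidazolyl ring bearing an alkyl group: a 6.3-fold lower number from compound 1 to compound 2 (0.80 log units; beyond the scatter) and a 17-fold lower number from compound 1 to compound 3 (1.22 log units; beyond the scatter). Between those two the alkyl group alone accounts for a 2.7-fold lower number from compound 2 to compound 3 (0.43 log units; beyond the scatter). Compound 4 carries methyl on its ring rather than ethyl or isopropyl, so the expected step is estimated as a 5.0-fold lower number from compound 1 to compound 4 (0.70 log units; beyond the scatter). For compound 4 the estimate is 280 nM, within 110 nM to 750 nM.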

Compound 4, half-maximal inhibitory concentration: 102 nM
Beside the measured number, compound 4's estimate is 2.7-fold (0.44 log units) above it, outside the stated range (below it).
By their numbers in this assay, from the lowest: compounds 3 and 4 (each within the scatter of the next); then compound 2; then compound 1.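

In this assay the 4-methyl-1H-imidazol-1-yl group gives a 14-fold lower number from compound 1 to compound 4 (1.14 log units; beyond the scatter) and, set against the 2-isopropyl-1H-imidazol-1-yl group, gives a 1.2-fold higher number from compound 3 to compound 4 (0.08 log units; within the scatter), so a large alkyl group on the imidazolyl ring is not needed to reach this range. The step of a 2.2-fold lower number from compound 2 to compound 4 (0.34 log units; beyond the scatter) shows that the numbers do not follow alkyl size alone, with compound 4 going against the order seen from compound 2 to compound 3. No evidence is available to explain these differences.

Methyl placement and ring substitution change together here, so their contributions cannot be separated. Going by these compounds, the 2-methyl-1H-imidazol-1-yl group and the unsubstituted imidazol-1-yl group on this carbon remain open.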